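Compound 4: stability beyond the shared limit?

The source may hold more compounds than are shown below. What is called first, only, known or untested is meant among the compounds shown, and "the series" means these compounds.

Measured in an ADME assay on microsomes from liver (Homo sapiens) for metabolic stability, read by LC-MS, with NADPH named in the record, with a stated time of 60 min, tested at 1 uM, in the absence of a further agent; a lower number here means that less of the compound is left, a higher number that more of the compound is left:
- Compound 1 `COc1ccc(-c2c(C)sc3c(N4CC[C@@H](NC(C)=O)C4)nc(C)nc23)cc1OC`: > 95%
- Compound 2 `COc1cc(-c2c(C)nc3c(N4CC[C@@H](NC(C)=O)C4)cc(C)nn23)cc(OC)c1OC`: > 95%
- Compound 3 `CC(=O)N[C@@H]1CCN(c2cc(C)nn3c(-c4ccc(C#N)cc4)c(C)nc23)C1`: > 95%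

Each of these three entries is a limit of the assay and not a number. The account follows compound 3, which gives > 95% in this assay, and this too is only a limit. The data hold (the limit of > 95% in this assay, at which 3 of the 3 values shown sit), so the three compounds cannot be ranked against one another.

Compound 4 `CSc1ccc(-c2c(C)nc3c(N4CC[C@@H](NC(C)=O)C4)cc(C)nn23)cc1` has not yet been measured. It carries methylsulfanyl in place of cyano on an aromatic carbon, para to a large group, so that 4-cyanophenyl becomes 4-(methylsulfanyl)phenyl: methylsulfanyl in place of cyano on an aromatic carbon.

Within the data shown here, no two measured compounds differ in one place only, so no measured step sets the size of this change. The limit also leaves open how far compound 3 stands from any number. A moderate downward move in this assay is nevertheless expected, though a result at the same limit remains possible. The estimated step is a number at least 15 percentage points lower from compound 3 to compound 4 (beyond the scatter). For compound 4 the expected value is 80%, with an estimated range of 55% to 98%.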

Compound 4, percent of the compound remaining: > 95%
Compound 4: only a limit was reported (the forecaster's own chance of this, stated with the estimate: 30%); middle value at least 15 percentage points from the limit.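

In this assay compound 4 gives > 95% as a limit of the assay and not a number. Among these compounds, no step from compound 3 to compound 4 can be read, because both compounds sit at the same limit: the limit of > 95% in this assay, at which 4 of the 4 values shown sit. The compounds shown leave open how methylsulfanyl and cyano compare in this assay and how far any of the four compounds stands from a number.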